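Triazole Aryl Swap on Two Lactone Cores

The source may hold more compounds than are shown below. What is called first, only, known or untested is meant among the compounds shown, and "the series" means these compounds.

Measured so far in a functional assay on HeLa cells (Homo sapiens) for antiproliferative activity, read by MTT assay, with a stated time of 72 h; on this read-out higher numbers stand for weaker inhibition and lower numbers for stronger inhibition:
Compound 1 `O=C1O[C@H]([C@@H](O)Cn2cc(-c3cccc(O)c3)nn2)C(OCc2ccccc2)=C1OCc1ccccc1`: compound 1 gives 39300 nM.
Compound 2 `COc1ccccc1-c1cn(C[C@H](O)[C@H]2OC(=O)C(OCc3ccccc3)=C2OCc2ccccc2)nn1`: compound 2 gives only the limit > 100000 nM.
Compound 3 `COc1ccccc1-c1cn(C/C=C2\OC(=O)C(OCc3ccccc3)=C2OCc2ccccc2)nn1`: compound 3 gives only the limit > 100000 nM.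

The difference between the core of compound 2 and the core of compound 3 is not broken down here. The step of an at least 2.5-fold lower number from compound 2 to compound 1 (0.40 log units; beyond the scatter) comes from 3-hydroxyphenyl in place of 2-methoxyphenyl on an aromatic carbon. The same change, (3-hydroxyphenyl in place of 2-methoxyphenyl on an aromatic carbon), leads from compound 3 to the unmeasured compound 4 `O=C1O/C(=C\Cn2cc(-c3cccc(O)c3)nn2)C(OCc2ccccc2)=C1OCc1ccccc1`. Because (the limit of > 100000 nM in this assay, at which 2 of the 3 values shown sit), the first step is known only as a bound, and the second starts from a limit as well, so a number for compound 4 may or may not be reached. Compound 4 is expected near 60000 nM in this assay, between 20000 nM and 200000 nM. The expected step of an at least 1.6-fold lower number from compound 3 to compound 4 (0.22 log units; that floor lies within the scatter) rests on an at least 2.5-fold lower number from compound 2 to compound 1 (0.40 log units; beyond the scatter) and is taken as at least similar in size.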

Compound 4, half-maximal inhibitory concentration: 74800 nM
Compound 4: the middle estimate sits 1.2-fold (0.10 log units) below what was measured; low and high end bracket the measured number.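

On the second core, 3-hydroxyphenyl in place of 2-methoxyphenyl gives an at least 1.3-fold lower number from compound 3 to compound 4 (0.12 log units; that floor lies within the scatter) in this assay. Set beside the step on the first core, the result reads: the same change on two cores in this assay, an at least 2.5-fold lower number (0.40 log units; beyond the scatter) from compound 2 to compound 1 and an at least 1.3-fold lower number (0.12 log units; that floor lies within the scatter) from compound 3 to compound 4; the limit leaves it open whether they differ. The change shows no reversal between the two cores, but the floor on the second core stays within the scatter and neither step has a defined size, so carrying over its size remains unshown: the limit of > 100000 nM in this assay, at which 2 of the 4 values shown sit.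

The compounds shown leave open whether the step belongs to the hydroxyl group or would also appear with a plain phenyl, an aminophenyl or a carboxyphenyl group on the triazole. Going by these compounds, how far the two cores differ when both carry 3-hydroxyphenyl also remains open.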